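Notes on the series: terminal amide substituent

This account rests on a few compounds, and the source may have more. Where it says the series, first, only, none or still open, it means among the compounds named here.

Two compounds of this series have numbers in an assay on isolated protein (Oryctolagus cuniculus) for inhibition of Calpain-2 catalytic subunit (Homo sapiens), at pH 8.0; a lower number here means a stronger inhibitor, a higher number a weaker inhibitor. Compound 1 `CCOC(=O)C(=O)C(CC)NC(=O)C(CC(C)C)NC(=O)CCc1ccccc1` gives 1200 nM in this assay. Compound 2 `CCCCNC(=O)C(=O)C(CC)NC(=O)C(CC(C)C)NC(=O)OCc1ccccc1` gives 50 nM in this assay, the lowest of the two numbers; its gap to compound 1 lies beyond the scatter, but the two differ in more than one place, so the numbers say only what each compound shows. Compound 3 `CCC(NC(=O)C(CC(C)C)NC(=O)OCc1ccccc1)C(=O)C(=O)NCCCc1ccccc1` has not been measured. It differs from compound 2 in one place: phenyl in place of methyl on a saturated chain carbon, three bonds along the chain from an amide-type nitrogen. Among the compounds with values here, no step of this kind between measured compounds is available, so the size of the step has to be estimated. Because compound 2 already stands at 50 nM and the change adds a six-membered aromatic ring of carbon only without a change in hydrogen-bond donors or acceptors, a small step or none beyond the scatter is expected in this assay. Compound 3 is expected to give 35 nM in this assay, within a range from 12 nM to 120 nM. This estimate corresponds to an expected 1.4-fold lower number from compound 2 to compound 3 (0.15 log units; within the scatter).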

Compound 3, inhibition constant: 43 nM
The estimate for compound 3 lay 1.2-fold (0.09 log units) below the measured number, and the stated range covers the measured number.
By their numbers in this assay, from the lowest: compounds 3 and 2 (each within the scatter of the next); then compound 1.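

In this assay, within the data shown here, this is the first comparison between compounds that differ in one place, and it reads a 1.2-fold lower number from compound 2 to compound 3 (0.07 log units; within the scatter) for the change from butyl to 3-phenylpropyl. At this position, therefore, phenyl in place of methyl adds one six-membered aromatic ring of carbon only, with 0 hydrogen-bond donors and 0 hydrogen-bond acceptors entering, and the two numbers cannot be told apart. Compound 1 could not show this, since it differs from both compounds in more than one place, and no measurement at hand bears on why the number holds across this change.

The compounds shown leave open whether benzyl or phenethyl would also stay within the scatter of butyl and 3-phenylpropyl, or whether a longer chain carrying the phenyl would do the same. They also leave open how the series would read with a basic amine, a carboxylic acid or a pyridine ring in place of the phenyl, as each of these would test more than added carbon.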